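A few compounds are considered here, and "the series" means these few. Any claim that something is new, unique, unknown or untested is made for them only; others in the source may bear on it.

Compound 2 `N#Cc1cccc(C2=NC(c3ccc(F)cc3)(c3ccc(F)cc3)CN2)c1` gives 2.7 nM in an assay on LM cells for displacement of a labelled ligand from Neuropeptide Y receptor type 5 (Homo sapiens) (a higher number here means a weaker inhibitor, a lower number a stronger inhibitor), and compound 1 `O=[N+]([O-])c1cccc(C2=NC(c3ccc(F)cc3)(c3ccc(F)cc3)CN2)c1` gives 4.3 nM; the step of a 1.6-fold lower number from compound 1 to compound 2 (0.20 log units; within the scatter) leaves the two standing level within the scatter. Compound 3 `O=Cc1cccc(C2=NC(c3ccc(F)cc3)(c3ccc(F)cc3)CN2)c1` differs from compound 2 by formyl in place of cyano on an aromatic carbon. Within the data shown here, the only step that speaks to a change at this aromatic carbon is the one from nitro to cyano, and it stayed within the scatter, so for the formyl group a step of about a 1.5-fold higher number from compound 2 to compound 3 (0.17 log units; within the scatter) in this assay is expected, none beyond the scatter. For compound 3 the estimate is 4 nM, with a range from 1.5 nM to 12 nM.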

Compound 3, half-maximal inhibitory concentration: 8.7 nM
The estimate for compound 3 lay 2.2-fold (0.34 log units) below the measured number; the measured number falls inside the stated range.
By their numbers in this assay, from the lowest: compounds 2 and 1 (each within the scatter of the next); then compound 3.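

At this aromatic carbon the group does matter: in this assay formyl in place of cyano gives a 3.2-fold higher number from compound 2 to compound 3 (0.51 log units; beyond the scatter) and formyl in place of nitro gives a 2.0-fold higher number from compound 1 to compound 3 (0.31 log units; beyond the scatter) and so, where nitro and cyano had stood level, this change moves the number beyond the scatter. Compound 3 is therefore the weakest of the three, though both steps are modest. Nothing available here explains this difference. On these data alone, how an amine, a carboxylic acid or a longer chain would fare at this carbon stays open. So does whether any group here can improve on compound 2 beyond the scatter.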